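The source may report more compounds than this note shows. Statements on the series, on what has been measured and on what is new or still open speak of the compounds shown alone.

Compound 1 `COc1ccc(OCc2cn(C(c3ccc(C#N)cc3)c3ccc(C#N)cc3)nn2)cc1` carries a methoxy group, and compound 2 `N#Cc1ccc(C(c2ccc(C#N)cc2)n2cc(COc3ccc(-c4ccccc4)cc3)nn2)cc1` carries a phenyl group in its stead. In an assay on isolated protein for inhibition of Aromatase (Homo sapiens), read by fluorescence and colorimetric assay, with a stated time of 30 min (on this read-out lower numbers stand for stronger inhibition and higher numbers for weaker inhibition), compound 1 gives 12200 nM, while compound 2 gives 13400 nM. The change between them, (phenyl in place of methoxy on an aromatic carbon), produced a 1.1-fold higher number from compound 1 to compound 2 (0.04 log units; within the scatter). Compound 3 `COc1ccc(OCc2cn(Cc3ccccc3)nn2)cc1` rests on a different core; the difference between the two cores is not broken down here. In this assay compound 3 gives 17300 nM. Compound 4 `c1ccc(Cn2cc(COc3ccc(-c4ccccc4)cc3)nn2)cc1` has not yet been measured in this assay. It differs from compound 3 by phenyl in place of methoxy on an aromatic carbon, the same change that separates compound 1 from compound 2, at a place described in exactly the same words. A similarly small step is expected for compound 4, because the measured 1.1-fold higher number from compound 1 to compound 2 (0.04 log units; within the scatter) lay within the scatter. The expected step is a 1.1-fold higher number from compound 3 to compound 4 (0.04 log units; within the scatter). Compound 4 is accordingly estimated at 19000 nM in this assay, with a likely range from 9000 nM to 40000 nM, pending the actual measurement.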

Compound 4, half-maximal inhibitory concentration: 10700 nM
For compound 4 the middle estimate is 1.8-fold (0.25 log units) above the measured one; low and high end bracket the measured number.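

Phenyl in place of methoxy on an aromatic carbon gave a 1.6-fold lower number from compound 3 to compound 4 (0.21 log units; within the scatter) in this assay. Set beside the same change on the core of compound 1, this step does not stand apart: the same change on two cores in this assay, a 1.1-fold higher number (0.04 log units; within the scatter) from compound 1 to compound 2 and a 1.6-fold lower number (0.21 log units; within the scatter) from compound 3 to compound 4, 1.8-fold (0.25 log units) apart, within the scatter of two such steps This shows that, on these two cores, the change carried over without any step or any gap between steps that rises above the scatter, so the earlier result was a fair guide to the size of the new one. It does not show that the change has no effect at all, since steps this small cannot be told from repeated-measurement noise, and two pairs say nothing about how the change would behave on a third core.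

The compounds shown leave open whether another group at this place, such as an amine, a carboxylic acid or a longer chain, would move the number beyond the scatter. They also leave open whether a group other than methoxy or phenyl would behave alike on both cores.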